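Cyclobutylcarbonyl piperazine replacing the hydroxypiperidine on the shared core

A few compounds are considered here, and "the series" means these few. Any claim that something is new, unique, unknown or untested is made for them only; others in the source may bear on it.

Compound 1 `CCC1(O)CCN(c2nc(C)c3cc(NC(=O)COc4ccc(OC(F)(F)F)cc4)ccc3n2)CC1`: 59 nM
Compound 2 `Cc1nc(N2CCC(N3CCCC3)CC2)nc2ccc(NC(=O)C(C)Oc3ccc(Cl)cc3)cc12`: 401 nM
Compound 3 `Cc1nc(N2CCC(O)CC2)nc2ccc(NC(=O)C(C)(C)Oc3ccc(Cl)cc3)cc12`: > 10000 nM

In a functional assay on CHO-K1 cells for antagonist activity at melanin-concentrating hormone receptor 1 (Homo sapiens), read by inositol phosphate accumulation (on this read-out higher numbers stand for weaker inhibition and lower numbers for stronger inhibition), compound 1 gives 59 nM, the lower of the two numbers recorded, and in this assay compound 2 gives 401 nM. For compound 3 the value in this assay is only a limit, > 10000 nM (the limit of > 10000 nM in this assay, at which 1 of the 3 values shown sits). Compound 4 `Cc1nc(N2CCN(C(=O)C3CCC3)CC2)nc2ccc(NC(=O)COc3ccc(OC(F)(F)F)cc3)cc12` has not yet been measured in this assay; it differs from compound 1 in one place: 4-(cyclobutylcarbonyl)piperazin-1-yl in place of 4-ethyl-4-hydroxypiperidin-1-yl on an aromatic carbon on an aromatic carbon of the shared core, between two ring nitrogen atoms. Among the compounds with values here, no single-change step between measured compounds is available, so the expected step from compound 1 to compound 4 is estimated at a 2.5-fold higher number from compound 1 to compound 4 (0.41 log units; beyond the scatter), a modest loss, with wide uncertainty. Compound 4 is therefore expected to give 150 nM, within 40 nM to 800 nM.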

Compound 4, half-maximal inhibitory concentration: 45 nM
The estimate for compound 4 lay 3.3-fold (0.52 log units) above the measured number, and the stated range covers the measured number.
By their numbers in this assay, from the lowest: compounds 4 and 1 (each within the scatter of the next); then compound 2. At a limit, above all of these: compound 3.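

In this assay, 4-(cyclobutylcarbonyl)piperazin-1-yl in place of 4-ethyl-4-hydroxypiperidin-1-yl gave a 1.3-fold lower number from compound 1 to compound 4 (0.12 log units; within the scatter). This position on the shared core therefore accepts a second, quite different ring system carrying a cyclobutyl ring and a carbonyl, and the value holds although the hydrogen-bond donor of the leaving group is gone. Nothing measured here gives a reason for this result. On these data alone, it remains open whether the cyclobutyl ring matters, or whether a smaller acetyl group, a phenyl ring or a sulfonyl group in place of the carbonyl on the piperazine would hold the value.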